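Swapping trifluoromethoxy for trifluoromethyl on the anilide ring

A few compounds are considered here, and "the series" means these few. Any claim that something is new, unique, unknown or untested is made for them only; others in the source may bear on it.

Of the compounds shown here, three have been tested in a functional assay on NALM-6 cells (Homo sapiens) for cytotoxicity, read by luminescence and CellTiter-Glo, with a stated time of 3 days; on this read-out lower numbers stand for stronger inhibition and higher numbers for weaker inhibition. Compound 1, with structure `O=C(Nc1ccc(OC(F)(F)F)cc1)c1cc(F)ccc1O`, gives 1210 nM. Compound 2, with structure `O=C(Nc1cc(C(F)(F)F)cc(C(F)(F)F)c1)c1ccc(-c2ccccc2)cc1O`, gives 1580 nM. Compound 3, with structure `O=C(Nc1ccc(OC(F)(F)F)c(Cl)c1)c1cc(F)ccc1O`, gives 1000 nM. Compound 1 thus stands second highest of the three numbers, but its gaps to both neighbours are within the scatter, so nothing separates the three.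

Going by the values given here, the only single-point step measured so far is a 1.2-fold lower number from compound 1 to compound 3 (0.08 log units; within the scatter), which adds chloro and changes nothing about the trifluoromethoxy group itself. Compound 4, with structure `O=C(Nc1ccc(C(F)(F)F)cc1)c1cc(F)ccc1O`, differs from compound 1 as follows: trifluoromethyl in place of trifluoromethoxy on an aromatic carbon. Among the compounds with values here, no measured step touches this group, so the data offer no direct guide.

Within the data shown here, with the closest measured step within the scatter and no step on the group that changes, the expectation for compound 4 in this assay is a number close to that of compound 1, estimated at 1200 nM with a range of 500 nM to 3000 nM, that is an expected step of a 1.0-fold lower number from compound 1 to compound 4 (0.00 log units; within the scatter).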

Compound 4, half-maximal inhibitory concentration: 2090 nM
Beside the measured number, compound 4's estimate is 1.7-fold (0.24 log units) below it; the measured number falls inside the stated range.
By their numbers in this assay, from the lowest: compounds 3, 1, 2 and 4 (each within the scatter of the next, the first and the last beyond it).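

Going by these compounds alone, this is the first measured step that touches the group at this place, on an aromatic carbon para to a large group. In this assay, trifluoromethyl in place of trifluoromethoxy gives a 1.7-fold higher number from compound 1 to compound 4 (0.24 log units; within the scatter), so taking out the oxygen that links the fluorinated carbon to the ring leaves a result that repeat measurements could not tell apart from compound 1. Nothing available here explains the numbers for this pair or says how either group acts on the cells.

From the compounds shown here alone, the swap has been read on the core of compound 1 alone, so it remains open whether it would give a similar step with the chloro group of compound 3 present. Also open, going by these compounds, is how a group without fluorine, such as methoxy, a nitrile or an amine, would read at this place.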